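Adding methyl groups to the phenyl ring

This account rests on a few compounds, and the source may have more. Where it says the series, first, only, none or still open, it means among the compounds named here.

compound 1 `Nc1nc(N)c2cc(CSC(=S)N3CCN(c4ccccc4)CC3)ccc2n1` at 4120 nM
compound 2 `Cc1ccc(N2CCN(C(=S)SCc3ccc4nc(N)nc(N)c4c3)CC2)cc1` at 5510 nM

Among the measured compounds shown here, in a functional assay on HCT-116 cells (Homo sapiens) for antiproliferative activity, read by MTT assay, with a stated time of 72 h (a lower number here means a stronger inhibitor, a higher number a weaker inhibitor), compound 1 gives 4120 nM as one of only two numbers so far. It stands within the scatter of compound 2, so neither can be ranked above the other. Compound 3 `Cc1ccc(N2CCN(C(=S)SCc3ccc4nc(N)nc(N)c4c3)CC2)c(C)c1` keeps the shared core and changes one group, with 2,4-dimethylphenyl in place of phenyl on an amine nitrogen in a ring as the whole difference.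

For the measured compounds named here, one measured step bears on this: a 1.3-fold higher number from compound 1 to compound 2 (0.13 log units; within the scatter) for methyl in place of hydrogen on an aromatic carbon. That step is small, so a similarly small move toward a higher number is expected in this assay, probably not beyond the scatter. The expected change is a 1.5-fold higher number from compound 1 to compound 3 (0.16 log units; within the scatter) as an estimate. The estimated value for compound 3 is 6000 nM with an expected range from 2500 nM to 14000 nM in this measurement.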

Compound 3, half-maximal inhibitory concentration: 4070 nM
For compound 3 the middle estimate is 1.5-fold (0.17 log units) above the measured one; the measured number falls inside the stated range.
By their numbers in this assay, from the lowest: compounds 3, 1 and 2 (each within the scatter of the next).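

In this assay, putting 2,4-dimethylphenyl in place of phenyl on the ring amine nitrogen gives a 1.0-fold lower number from compound 1 to compound 3 (0.01 log units; within the scatter), so a larger group with two methyl groups at this position still leaves the number within the scatter. The further methyl on the aromatic ring gives a 1.4-fold lower number from compound 2 to compound 3 (0.13 log units; within the scatter), which means that going from one methyl group to two also brings no readable change, and compounds 1, 2 and 3 cannot be ranked against one another. No measured evidence bears on this result.

All three compounds carry only hydrogen or methyl on this phenyl ring, so these numbers say little about other kinds of substituent. On these data alone, it remains open whether a methoxy group, a chlorine atom or a carboxylic acid on the ring would move the number beyond the scatter.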